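This account rests on a few compounds, and the source may have more. Where it says the series, first, only, none or still open, it means among the compounds named here.

In an assay on isolated protein for inhibition of Polyunsaturated fatty acid 5-lipoxygenase (Homo sapiens), read by HPLC, with a stated time of 15 min, in the presence of a further agent that is not named here (on this read-out lower numbers stand for stronger inhibition and higher numbers for weaker inhibition), two compounds have been measured. Compound 1 `CC(C)(C)c1ccc(CN2CCN(C(=O)CCc3cc(-c4ccc(C(F)(F)F)cc4)n(-c4ccc(Cl)cc4)n3)CC2)cc1` gives 8000 nM. Compound 2 `CC(C)(C)c1ccc(CN2CCN(C(=O)CCc3cc(-c4ccc(F)cc4)n(-c4ccc5ccccc5n4)n3)CC2)cc1` gives 2800 nM, the lowest of the two numbers, with compound 1 standing beyond the scatter above it. Compound 3 `CC(C)(C)c1ccc(CN2CCN(C(=O)CCc3cc(-c4ccc(C(F)(F)F)cc4)n(-c4ccc5ccccc5n4)n3)CC2)cc1` has not yet been measured in this assay. It differs from compound 2 in one place: trifluoromethyl in place of fluoro on an aromatic carbon. No measured pair in this set isolates this change, so the step from compound 2 to compound 3 cannot be read from a shown difference, and the two values in hand do not tell the size or direction of a single group swap. The expected step from compound 2 to compound 3 is therefore a 1.3-fold higher number from compound 2 to compound 3 (0.10 log units; within the scatter), a step not clearly beyond the scatter. Compound 3 is estimated at 3500 nM, with a range from 1200 nM to 10000 nM.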

Compound 3, half-maximal inhibitory concentration: 3000 nM
The estimate for compound 3 lay 1.2-fold (0.07 log units) above the measured number; the range from low to high includes it.
By their numbers in this assay, from the lowest: compounds 2 and 3 (each within the scatter of the next); then compound 1.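

In this assay, trifluoromethyl in place of fluoro on this aromatic carbon, para to a large group, gives a 1.1-fold higher number from compound 2 to compound 3 (0.03 log units; within the scatter), so with quinolin-2-yl on the aromatic nitrogen, these two groups cannot be told apart here, although one has 4 heavy atoms and the other 1. With 4-(trifluoromethyl)phenyl held in place, quinolin-2-yl in place of 4-chlorophenyl on the aromatic nitrogen gives a 2.7-fold lower number from compound 1 to compound 3 (0.43 log units; beyond the scatter), a modest step that isolates that change alone. Nothing at hand bears on the cause of either step.

As far as these compounds go, it remains open whether a methoxy group, an amine or a carboxylic acid at the same aromatic carbon would read like fluoro and trifluoromethyl. From the compounds shown here alone, it is also open whether those two groups would still match with 4-chlorophenyl on the aromatic nitrogen.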